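The source may hold more compounds than are shown below. What is called first, only, known or untested is meant among the compounds shown, and "the series" means these compounds.

In an ADME assay on HepG2 cells (Homo sapiens) for cytotoxicity, read by MTT assay, with a stated time of 72 h (a higher number here means that more compound is tolerated, a lower number that less compound is tolerated), compound 1 (`CC(C)(C)Nc1nc2cc(-c3ccc(Br)cc3)sc2c(=O)[nH]1`) gives 1400 nM, the lowest of the three measured numbers. Compound 2 (`COc1ccc(-c2cc3nc(NC(C)(C)C)[nH]c(=O)c3s2)cc1`) gives 32300 nM, and compound 3 (`CC(C)Nc1nc2cc(-c3ccc(Br)cc3)sc2c(=O)[nH]1`) gives 13400 nM. Compound 4 (`CC(C)(C)Nc1nc2ccsc2c(=O)[nH]1`) is unmeasured. Its change from compound 1 is hydrogen in place of 4-bromophenyl on an aromatic carbon. For the measured compounds named here, no measured step removes this group. The closest evidence is a 23-fold higher number from compound 1 to compound 2 (1.36 log units; beyond the scatter), with methoxy in place of bromo, a large step. A modest step on the saturated chain, a 9.6-fold higher number from compound 1 to compound 3 (0.98 log units; beyond the scatter), points the same way. A rise in this assay is therefore expected, though this is uncertain. The expected change is a 29-fold higher number from compound 1 to compound 4 (1.46 log units; beyond the scatter). For compound 4 the estimated value is 40000 nM, with an expected range of 12000 nM to 100000 nM.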

Compound 4, half-maximal cytotoxic concentration: 8400 nM
The estimate for compound 4 lay 4.8-fold (0.68 log units) above the measured number, and the stated range ends above it.
By their numbers in this assay, from the lowest: compound 1; then compounds 4 and 3 (each within the scatter of the next); then compound 2.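

In this assay, the step to hydrogen at this carbon next to the ring sulfur, a 6.0-fold higher number from compound 1 to compound 4 (0.78 log units; beyond the scatter), shows that the low number of compound 1 depends on the 4-bromophenyl group as a whole being present. This step is smaller than a 23-fold higher number from compound 1 to compound 2 (1.36 log units; beyond the scatter), so a substituted phenyl here can sit on either side of hydrogen: compound 1 lies below compound 4, and compound 2 lies above it. No measurement offered bears on the reason for this. Open, from the compounds shown here alone, is where an unsubstituted phenyl or a chloro or carboxylic acid in place of bromo would fall.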